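Pyridin-2-yl in place of 4-aminophenyl

The source may hold more compounds than are shown below. What is called first, only, known or untested is meant among the compounds shown, and "the series" means these compounds.

In a functional assay on HepG2 cells (Homo sapiens) for inhibition, read by MTT assay, with a stated time of 72 h (on this read-out lower numbers stand for stronger inhibition and higher numbers for weaker inhibition), compound 1 `CC(C)(C)n1cc2c(n1)C(=O)CC1(CCN(C(=O)c3cc(-c4ccc(Br)cc4)nc4ccccc34)CC1)O2` gives 820 nM and compound 2 `CC(C)(C)n1cc2c(n1)C(=O)CC1(CCN(C(=O)c3cc(-c4ccc(N)cc4)nc4ccccc34)CC1)O2` gives 630 nM, so the two lie within the usual scatter of each other. Compound 3 `CC(C)(C)n1cc2c(n1)C(=O)CC1(CCN(C(=O)c3cc(-c4ccccn4)nc4ccccc34)CC1)O2`, not yet measured, keeps the shared core of compound 2 but carries pyridin-2-yl in place of 4-aminophenyl on an aromatic carbon, next to the ring nitrogen: pyridin-2-yl in place of 4-aminophenyl on an aromatic carbon. Going by the values given here, only one measured step bears on this change: a 1.3-fold lower number from compound 1 to compound 2 (0.11 log units; within the scatter), amino in place of bromo on an aromatic carbon. That step stays within the scatter, but it leaves the aromatic ring itself unchanged, so the data offer no direction for replacing it. Going by these compounds, no shift beyond the scatter is therefore expected, though this remains untested. The expected step is a 1.3-fold higher number from compound 2 to compound 3 (0.10 log units; within the scatter). Compound 3 is estimated at 800 nM, with an expected range from 280 nM to 2300 nM.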

Compound 3, half-maximal inhibitory concentration: 1500 nM
Compound 3: the middle estimate sits 1.9-fold (0.27 log units) below what was measured; the range from low to high includes it.
By their numbers in this assay, from the lowest: compounds 2, 1 and 3 (each within the scatter of the next, the first and the last beyond it).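

In this assay, going by these compounds alone, pyridin-2-yl in place of 4-aminophenyl produces the first step in this small set that lies beyond the scatter (a 2.4-fold higher number from compound 2 to compound 3 (0.38 log units; beyond the scatter)), and it is a modest one. This is also the first change shown that replaces the aromatic ring on this carbon rather than only its substituent, yet pyridin-2-yl in place of 4-bromophenyl stays within the scatter (a 1.8-fold higher number from compound 1 to compound 3 (0.26 log units; within the scatter)), so the separation holds against 4-aminophenyl alone. Nothing available accounts for this difference.

The step from 4-aminophenyl to pyridin-2-yl alters the ring and removes the amino group at once, so the compounds shown leave open which of the two matters. A plain phenyl group or a pyridin-3-yl group on this carbon would help to separate them.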